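This account rests on a few compounds, and the source may have more. Where it says the series, first, only, none or still open, it means among the compounds named here.

Compound 1, `Oc1ccc(-c2cc(-c3ccccc3OC(F)(F)F)cc(-c3cccc(O)c3)n2)cc1`, is one of three measured compounds built on a shared core that carries a trifluoromethoxy-bearing ring and two hydroxyphenyl rings. In a functional assay on T47D cells (Homo sapiens) for inhibition (on this read-out lower numbers stand for stronger inhibition and higher numbers for weaker inhibition), compound 1 gives 7300 nM. Compound 3, `Oc1ccc(-c2cc(-c3ccccc3OC(F)(F)F)cc(-c3ccc(O)cc3)n2)cc1`, keeps the same atoms joined differently: the change is 4-hydroxyphenyl in place of 3-hydroxyphenyl on an aromatic carbon. In this assay compound 3 gives 9840 nM, and the step is a 1.3-fold higher number from compound 1 to compound 3 (0.13 log units; within the scatter), so the two values lie within the scatter of one another.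

Compound 2, `Oc1ccc(-c2cc(-c3cccc(OC(F)(F)F)c3)cc(-c3cccc(O)c3)n2)cc1`, differs from compound 1 in the placement of the trifluoromethoxy group, and the difference between the two cores is not broken down here. In this assay compound 2 gives 5040 nM; its value sits within the scatter of both compound 1 and compound 3, so no order among the three can be drawn.

Compound 4, `Oc1ccc(-c2cc(-c3cccc(OC(F)(F)F)c3)cc(-c3ccc(O)cc3)n2)cc1`, has not yet been measured in this assay. It stands to compound 2 as compound 3 stands to compound 1: the change is 4-hydroxyphenyl in place of 3-hydroxyphenyl on an aromatic carbon, the same change at the same place. For the measured compounds named here, because the only measured example of this change, a 1.3-fold higher number from compound 1 to compound 3 (0.13 log units; within the scatter), stayed within the scatter, the expected step from compound 2 to compound 4 in this assay is a 1.3-fold higher number from compound 2 to compound 4 (0.11 log units; within the scatter), likewise small. The value of compound 4 in this assay is therefore estimated at 6500 nM, with a range from 3300 nM to 13000 nM.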

Compound 4, half-maximal inhibitory concentration: > 50000 nM
Compound 4: only a limit was reported (the forecaster's own chance of this, stated with the estimate: 5%); middle value at least 7.6-fold (0.88 log units) away from the limit.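

In this assay compound 4 gives > 50000 nM, which is a limit of the assay and not a number. Read from that limit, the change to 4-hydroxyphenyl in place of 3-hydroxyphenyl gives an at least 9.9-fold higher number from compound 2 to compound 4 (0.99 log units; beyond the scatter), and so it does not carry over at one size from the core of compound 1 to the core of compound 2: the same change on two cores in this assay, a 1.3-fold higher number (0.13 log units; within the scatter) from compound 1 to compound 3 and an at least 9.9-fold higher number (0.99 log units; beyond the scatter) from compound 2 to compound 4, at least 7.3-fold (0.86 log units) apart, beyond the scatter of two such steps This shows that the outcome of the change depends on the core in these two pairs, but it does not give the full size of the second step, nor does it show what in the placement of the trifluoromethoxy group makes the two cores respond differently, or how the change would behave on any further core.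

The compounds shown leave open whether the step seen with compound 4 belongs to the 4-hydroxyphenyl group at that place alone or to its combination with both the second hydroxyphenyl ring and the trifluoromethoxy group. They also leave open what would follow on these cores if a methoxy group, an amine or a carboxylic acid stood in place of the hydroxyl on either hydroxyphenyl ring.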